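Side-chain exchange: from compound 2 to compound 3

The source may hold more compounds than are shown below. What is called first, only, known or untested is meant among the compounds shown, and "the series" means these compounds.

Measured so far in a functional assay on A549 cells (Homo sapiens) for cytotoxicity, read by MTT assay, with a stated time of 48 h; on this read-out higher numbers stand for weaker inhibition and lower numbers for stronger inhibition:
- Compound 1 `CCCCNCCCCOc1c(O)cc(O)c2c(=O)cc(-c3ccccc3)oc12`: "not determined" (no result reported)
- Compound 2 `COc1c(OCc2ncc(C)o2)cc(O)c2c(=O)cc(-c3ccccc3)oc12`: > 100000 nM

Compound 1 has no result and gives no anchor for the series. Compound 2 sits at > 100000 nM, which is a limit of the assay and not a number. The only fixed point is therefore (the limit of > 100000 nM in this assay, at which 1 of the 2 values shown sits).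

The next compound to be read is compound 3 `CCN(CC)CCCOc1cc(O)c2c(=O)cc(-c3ccccc3)oc2c1OC`. Its difference from compound 2 is 2-(diethylamino)ethyl in place of 5-methyl-1,3-oxazol-2-yl on a saturated chain carbon bound to an oxygen on an aromatic ring. In short, 2-(diethylamino)ethyl takes the place of 5-methyl-1,3-oxazol-2-yl on a saturated chain carbon bound to an oxygen on an aromatic ring.

Among the compounds with values here, no measured step in this assay covers this change, so the expectation rests on the limit of compound 2 and on the structural change alone. A moderate move towards stronger inhibition is expected, although a second reading at the limit remains quite possible. The expected size is an at least 2.5-fold lower number from compound 2 to compound 3 (0.39 log units; beyond the scatter). For compound 3 the estimated value is 40000 nM. The expected range for compound 3 runs from 12000 nM to 100000 nM.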

Compound 3, half-maximal inhibitory concentration: 1830 nM
For compound 3 the middle estimate is 22-fold (1.34 log units) above the measured one; the whole stated range lies above it.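

In this assay, within the data shown here, 2-(diethylamino)ethyl in place of 5-methyl-1,3-oxazol-2-yl on a saturated chain carbon bound to an oxygen on an aromatic ring gives an at least 54-fold lower number from compound 2 to compound 3 (1.73 log units; beyond the scatter), which shows that the read-out at this position responds strongly to the side chain, something the earlier compounds could not show. Among these compounds, compound 3, at 1830 nM, supplies the first single number of the series and so the first real anchor for later comparisons. The true size of the step stays unknown and only its lower bound is fixed, because the starting point is a limit and not a number: the limit of > 100000 nM in this assay, at which 1 of the 3 values shown sits.

The exchange changes several things at once, as the same difference read one bond further out is (5-methyl-1,3-oxazol-2-yl)methyl to 3-(diethylamino)propyl, so the compounds shown cannot separate the loss of the five-membered aromatic ring, the arrival of the tertiary amine and the longer chain. Open as well is how a morpholine or a piperidine at the end of the same propyl chain would read, and whether a shorter ethyl chain carrying the diethylamine would hold the gain.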